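From hydroxycarbamoyl to carboxy: cytotoxicity on liver cells

A few compounds are considered here, and "the series" means these few. Any claim that something is new, unique, unknown or untested is made for them only; others in the source may bear on it.

Compound 1 `O=C1CCC2(CC1)OCC1(OO2)C2CC3CC(C2)CC1C3`: > 100000 nM
Compound 2 `Oc1ccc(N[C@H]2CC[C@]3(CC2)OO[C@]2(O3)C3CC4CC(C3)CC2C4)c2cccnc12`: 25700 nM
Compound 3 `O=C(NO)[C@H]1CC[C@]2(CC1)OO[C@]1(O2)C2CC3CC(C2)CC1C3`: > 50000 nM

All three share one core and were tested in an ADME assay on L02 cells (Homo sapiens) for cytotoxicity, read by MTT assay, with a stated time of 48 h; a higher number here means a weaker inhibitor, a lower number a stronger inhibitor. For compound 1 the result is a limit of the assay, not a number (the limit of > 100000 nM in this assay, at which 1 of the 3 values shown sits). Compound 2 gives a measured number in this assay, 25700 nM. For compound 3 the result is again a limit, not a number (the limit of > 50000 nM in this assay, at which 1 of the 3 values shown sits). So compound 3 sits among the values where the assay reports only a limit, with one other compound in the same position and only compound 2 giving an actual figure.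

Compound 4 `O=C(O)[C@H]1CC[C@]2(CC1)OO[C@]1(O2)C2CC3CC(C2)CC1C3` has not yet been measured in this assay. It differs from compound 3 in one place: hydroxy in place of hydroxyamino on a carbonyl carbon. Among the compounds with values here, no measured step between any two of the compounds above is available, so there is nothing to compare this change against directly. The step from compound 3 to compound 4 is expected to be small, a step that the limit leaves unreadable from compound 3 to compound 4, within the usual scatter. Compound 4 is therefore estimated at 80000 nM, somewhere between 25000 nM and 300000 nM, most likely reported as a limit once more.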

Compound 4, half-maximal inhibitory concentration: > 100000 nM
Compound 4: no number, only a limit; the forecaster's own chance of this, stated with the estimate: 80%; middle value at least 1.2-fold (0.09 log units) away from the limit.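

Compound 3 and compound 4 each give only a limit in this assay, not a number, so no step can be read between them. The compounds shown leave open whether changing hydroxycarbamoyl to carboxy shifts this read-out at all, and in which direction.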